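Nitrocatechol oxadiazoles: removing the methyl from compound 2

A few compounds are considered here, and "the series" means these few. Any claim that something is new, unique, unknown or untested is made for them only; others in the source may bear on it.

Two members of the series have a number in a functional assay on the whole organism (liver, strain Wistar) for inhibition, with Rattus norvegicus as the target, with a stated time of 3 h, at a dose of 3 mg/kg by the oral route (on this read-out lower numbers stand for less inhibition and higher numbers for more inhibition at the one dose given (going by the name of the read-out)), so far. Compound 1 `O=[N+]([O-])c1cc(-c2nc(-c3ccc[n+]([O-])c3)no2)cc(O)c1O` gives 77% in this assay. Compound 2 `Cc1c(-c2noc(-c3cc(O)c(O)c([N+](=O)[O-])c3)n2)ccc(C(F)(F)F)[n+]1[O-]` gives 13.9%, the lowest of the two numbers; its nearest neighbour is compound 1, whose number lies higher by an amount beyond the scatter. For the measured compounds named here, no pair among the measured compounds differs in a single place, so no measured step is available to guide the next one.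

Compound 3 `O=[N+]([O-])c1cc(-c2nc(-c3ccc(C(F)(F)F)[n+]([O-])c3)no2)cc(O)c1O` is the next target in this assay. Relative to compound 2 the change is hydrogen in place of methyl on an aromatic carbon. Going by the values given here, compound 3 keeps the trifluoromethyl group of compound 2 but loses the methyl, so it sits between compound 2 and compound 1 in make-up, and with only two numbers the expectation rests on that position alone.

For compound 3 a step of a number 21.1 percentage points higher from compound 2 to compound 3 (beyond the scatter) towards more inhibition is expected, the direction of compound 1 with its 77%, though the size is uncertain. Compound 3 is estimated at 35%, with a range from 10% to 65%.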

Compound 3, a percentage reported as inhibition, in the whole organism at one dose (the size of the read-out at that dose, not a potency): 34.4%
Estimate against measurement, compound 3: 0.6 percentage points above; the measured number falls inside the stated range.
By their numbers in this assay, from the lowest: compound 2; then compound 3; then compound 1.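

In this assay, hydrogen in place of methyl on an aromatic carbon next to the ring nitrogen gives a number 20.5 percentage points higher from compound 2 to compound 3 (beyond the scatter), the first measured sign that the group at this position matters to the read-out while the trifluoromethyl group stays in place. Trifluoromethyl in place of hydrogen on an aromatic carbon gives a number 42.6 percentage points lower from compound 1 to compound 3 (beyond the scatter), so the wide gap between the two earlier compounds now divides into two single changes, a modest one for the methyl and a large one for the trifluoromethyl, both beyond the usual scatter. No measurement at hand explains either step.

The compounds shown leave open whether the methyl would give a step of the same direction and size without the trifluoromethyl group, since no compound carries the methyl alone. They also leave open how the position next to the ring nitrogen would respond to an ethyl group, a methoxy group or an amine, and how the trifluoromethyl position would respond to a chlorine atom or a nitrile.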